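Swapping the furan for phenyl on a weak cytotoxic lead

The source may report more compounds than this note shows. Statements on the series, on what has been measured and on what is new or still open speak of the compounds shown alone.

Measured compounds:
Compound 1 `Oc1cccc(-c2cc(-c3ccc(Cl)cc3)nc(-c3ccco3)c2)c1`: 11400 nM
Compound 2 `Oc1cccc(-c2cc(-c3ccco3)nc(-c3ccccc3Cl)c2)c1`: 1630 nM
Compound 3 `Oc1cccc(-c2cc(-c3cccc(Cl)c3)nc(-c3ccco3)c2)c1`: 2020 nM

In a functional assay on DU-145 cells (Homo sapiens) for cytotoxicity, read by CCK-8 assay and cell counting, with a stated time of 2 days (on this read-out lower numbers stand for stronger inhibition and higher numbers for weaker inhibition), compound 1 gives the highest number of the three. The move to compound 2 brings a 7.0-fold lower number from compound 1 to compound 2 (0.84 log units; beyond the scatter), and the move to compound 3 brings a 5.6-fold lower number from compound 1 to compound 3 (0.75 log units; beyond the scatter), while between compound 2 and compound 3 there is only a 1.2-fold higher number from compound 2 to compound 3 (0.09 log units; within the scatter). Compound 4 `Oc1cccc(-c2cc(-c3ccccc3)nc(-c3ccc(Cl)cc3)c2)c1` differs from compound 1 in another way: phenyl in place of furan-2-yl on an aromatic carbon. For the measured compounds named here, none of the measured steps touches this change; all of them concern where the chlorine sits on the chlorophenyl ring, and the 4-chlorophenyl group of compound 1 is kept in compound 4. Without any step that bears on it, compound 4 is expected to stay close to compound 1, with a step of a 1.4-fold lower number from compound 1 to compound 4 (0.15 log units; within the scatter). Compound 4 is therefore estimated at 8000 nM, within 2500 nM to 25000 nM.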

Compound 4, half-maximal inhibitory concentration: 11200 nM
The estimate for compound 4 lay 1.4-fold (0.15 log units) below the measured number; the range from low to high includes it.
By their numbers in this assay, from the lowest: compounds 2 and 3 (each within the scatter of the next); then compounds 4 and 1 (each within the scatter of the next).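

At the carbon next to the ring nitrogen, phenyl in place of furan-2-yl makes no difference beyond the scatter in this assay (a 1.0-fold lower number from compound 1 to compound 4 (0.01 log units; within the scatter)). With the 4-chlorophenyl group kept, this position therefore tolerates a six-membered carbon ring in place of a five-membered ring bearing a hydrogen-bond acceptor, though compound 4 gains nothing over compound 1. No available evidence explains this result.

On these data alone, it remains open whether phenyl behaves the same alongside the 2-chlorophenyl and 3-chlorophenyl groups. Also open, as far as these compounds go, is how a non-aromatic group, such as an amine or a carboxylic acid, would fare at this position.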